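Chloro for bromo on the fluorophenyl of compound 2

The source may report more compounds than this note shows. Statements on the series, on what has been measured and on what is new or still open speak of the compounds shown alone.

Compound 1 `CC(=O)Nc1ccc(S(=O)(=O)NNc2ccc(F)cc2)cc1` gives 609 nM in an assay on HeLa cells for inhibition of Indoleamine 2,3-dioxygenase 1 (Homo sapiens), read by spectrophotometry, with a stated time of 24 h; a higher number here means that more compound is needed for the effect, a lower number that less compound is needed. Within the data shown here, compound 2 `CC(=O)Nc1ccc(S(=O)(=O)NNc2ccc(F)c(Br)c2)cc1` gives 2490 nM in this assay, the highest of the two numbers; its only neighbour is compound 1, and the gap between them is a 4.1-fold higher number from compound 1 to compound 2 (0.61 log units; beyond the scatter). Compound 3 `CC(=O)Nc1ccc(S(=O)(=O)NNc2ccc(F)c(Cl)c2)cc1` differs from compound 2 by chloro in place of bromo on an aromatic carbon. Among the measured compounds shown here, no measured step exchanges one halogen for another; the single step in this assay, a 4.1-fold higher number from compound 1 to compound 2 (0.61 log units; beyond the scatter), concerns bromo entering for hydrogen and bears on the present change only loosely. The expected step is therefore small, a 1.4-fold lower number from compound 2 to compound 3 (0.14 log units; within the scatter), within the scatter. Compound 3 is estimated at 1800 nM, with a range from 700 nM to 4500 nM.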

Compound 3, half-maximal effective concentration: 2590 nM
Beside the measured number, compound 3's estimate is 1.4-fold (0.16 log units) below it; low and high end bracket the measured number.
By their numbers in this assay, from the lowest: compound 1; then compounds 2 and 3 (each within the scatter of the next).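

In this assay, the step between the two halogens at this position, ortho to a fluoro group, is a 1.0-fold higher number from compound 2 to compound 3 (0.02 log units; within the scatter) and leaves chloro and bromo indistinguishable here. Chloro in place of hydrogen gives a 4.3-fold higher number from compound 1 to compound 3 (0.63 log units; beyond the scatter) and so shows that the cost seen with bromo is not confined to bromo, at least across these two halogens. Nothing at hand accounts for this shared cost.

Open, on these data alone, are a methyl, methoxy or amine at this position in place of the halogen. Also open, as far as these compounds go, is whether the same cost holds without the fluoro group.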